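A few compounds are considered here, and "the series" means these few. Any claim that something is new, unique, unknown or untested is made for them only; others in the source may bear on it.

Measured so far: compound 1 `Cc1nc(C)n(CC(=O)N2CCN(c3sc(C(F)(F)F)nc3-c3nc4ccc(OC5COC5)cc4[nH]3)C[C@H]2C)n1` gives 68 nM in a functional assay on CHO-K1 cells for antagonist activity at C-X-C chemokine receptor type 3 (Homo sapiens), read by FLIPR, with a stated time of 10 min, in the presence of a further agent that is not named here; on this read-out higher numbers stand for weaker inhibition and lower numbers for stronger inhibition; compound 2 `Cc1nc(C)n(CC(=O)N2CCN(c3sc(C(F)(F)F)nc3-c3nc4ccccc4[nH]3)C[C@H]2C)n1` gives 3.2 nM.

Compound 2 holds the lowest number of the two. Compound 3 `Cc1nc(C)n(CC(=O)N2CCN(c3sc(C(F)(F)F)nc3-c3nc4ccc(S(C)(=O)=O)cc4[nH]3)C[C@H]2C)n1` differs from compound 2 by methylsulfonyl in place of hydrogen on an aromatic carbon. Going by the values given here, one measured step bears on this: the substituent change a 21-fold lower number from compound 1 to compound 2 (1.33 log units; beyond the scatter) shows that removing a group from the aromatic carbon of the shared core lowered the number sharply. Adding methylsulfonyl is expected to move the number back up, though less far than the oxetanyl ether did, with compound 3 estimated at a 7.8-fold higher number from compound 2 to compound 3 (0.89 log units; beyond the scatter). Compound 3 is therefore expected at 25 nM, within 6 nM to 100 nM.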

Compound 3, half-maximal inhibitory concentration: 10 nM
For compound 3 the middle estimate is 2.5-fold (0.40 log units) above the measured one; the measured number falls inside the stated range.
By their numbers in this assay, from the lowest: compound 2; then compound 3; then compound 1.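

In this assay, the number at this aromatic carbon depends on which group enters, not only on whether one is present: methylsulfonyl gives a 3.1-fold higher number from compound 2 to compound 3 (0.49 log units; beyond the scatter), and replacing (oxetan-3-yl)oxy with methylsulfonyl gives a 6.8-fold lower number from compound 1 to compound 3 (0.83 log units; beyond the scatter). Both substituents leave the number above that of hydrogen, so neither matches compound 2. No measurement here accounts for the gap between the two groups.

Open, going by these compounds, is whether fluorine, a methyl group, an amine or a carboxylic acid on this carbon would match hydrogen. Also open, on these data alone, is whether this order holds when another part of the shared core changes.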